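A few compounds are considered here, and "the series" means these few. Any claim that something is new, unique, unknown or untested is made for them only; others in the source may bear on it.

Compound 1 `CC(C)(C)OC(=O)N/N=C/c1c(N)ncnc1Oc1ccc(NC(=O)C2(C(=O)Nc3ccc(F)cc3)CC2)cc1F`: 3.7
Compound 2 `CC(O)CO/N=C/c1c(N)ncnc1Oc1ccc(NC(=O)C2(C(=O)Nc3ccc(F)cc3)CC2)cc1F`: 2.75
Compound 3 `Nc1ncnc(Oc2ccc(NC(=O)C3(C(=O)Nc4ccc(F)cc4)CC3)cc2F)c1/C=N/O`: 2.62
Compound 4 `Nc1ncnc(Oc2ccc(NC(=O)C3(C(=O)Nc4ccc(F)cc4)CC3)cc2F)c1/C=N/OCC(=O)N1CCOCC1`: not yet measured

In a physicochemical assay for lipophilicity, using the shake flask method (a lower number here means a more polar compound, a higher number a more lipophilic compound), compound 2 gives 2.75, the second highest of the three numbers; compound 3 lies nearest with 2.62, while compound 1 stands furthest away at 3.7. The move to compound 4 is (morpholin-4-yl)carbonyl in place of 1-hydroxyethyl on a saturated chain carbon bound to an oxygen on an unsaturated carbon. For the measured compounds named here, only one measured step touches the same arm: a number 0.13 log units lower from compound 2 to compound 3 (within the scatter), which stayed within the scatter. The two larger steps, a number 0.95 log units lower from compound 1 to compound 2 (beyond the scatter) and a number 1.08 log units lower from compound 1 to compound 3 (beyond the scatter), concern a different exchange and offer no direct guide. Since removing the whole arm in compound 3 hardly moved the number, no step beyond the scatter is expected here. Compound 4 is therefore estimated at 2.7, with a range from 2.2 to 3.2. That expectation amounts to a number 0.05 log units lower from compound 2 to compound 4 (within the scatter).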

Compound 4, partition coefficient: 2.1
Compound 4: middle estimate off by 0.60 log units, on the high side; the whole stated range lies above it.
By their numbers in this assay, from the lowest: compound 4; then compounds 3 and 2 (each within the scatter of the next); then compound 1.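

In this assay, the arm on this oxygen does matter: a number 0.52 log units lower from compound 3 to compound 4 (beyond the scatter), and a number 0.65 log units lower from compound 2 to compound 4 (beyond the scatter), although hydrogen and 2-hydroxypropyl there stayed within the scatter of each other. Replacing the (tert-butoxycarbonyl)amino group with ((morpholin-4-yl)carbonyl)methoxy gives a number 1.60 log units lower from compound 1 to compound 4 (beyond the scatter). Nothing measured here explains the shift.

Still open, going by these compounds, is whether the carbonyl or the morpholine ring accounts for it. A dimethylamide or a carboxylic acid on the same saturated chain carbon could separate the two.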